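The source may hold more compounds than are shown below. What is called first, only, known or untested is meant among the compounds shown, and "the series" means these compounds.

Three compounds share a core that carries a methylpiperazine on a fused bicyclic ring system. Compound 1 `Cc1cc(Cl)cc2nc(N3CCN(C)CC3)oc12` gives 6.7 in a functional assay on ileum (strain Hartley) for agonist activity at 5-hydroxytryptamine receptor 3A (Cavia porcellus) (on this read-out higher numbers stand for higher potency (the scale is a negative logarithm) and lower numbers for lower potency), compound 3 `CN1CCN(c2nc3cc(Cl)cc(Cl)c3o2)CC1` gives 6.51, and compound 2 `CN1CCN(c2nc3cc(F)ccc3o2)CC1` gives 5.57. On these numbers compound 2 stands lowest, beneath compound 3 and beneath compound 1 by more than the usual scatter in both cases. Compound 4 `CN1CCN(c2nc3cc(Br)ccc3o2)CC1` differs from compound 2 by bromo in place of fluoro on an aromatic carbon. Going by the values given here, the only step measured between compounds that differ in one place is a number 0.19 log units lower from compound 1 to compound 3 (within the scatter), a swap of chloro for methyl at a different site, which touches the present change only loosely: it suggests that one small substituent exchanged for another on the aromatic ring may move this assay little. Among the compounds with values here, no step measures fluoro against bromo directly. The gap between compound 2 and compound 3, which both carry halogen but differ elsewhere, leaves room for a rise. Compound 4 is therefore expected to show a modest increase, a number 0.53 log units higher from compound 2 to compound 4 (beyond the scatter), with an estimated value of 6.1 within a range of 5.5 to 6.7.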

Compound 4, negative logarithm of the half-maximal effective concentration: 6.21
Compound 4: middle estimate off by 0.11 log units, on the low side; the measured number falls inside the stated range.
By their numbers in this assay, from the lowest: compound 2; then compounds 4, 3 and 1 (each within the scatter of the next, the first and the last beyond it).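

In this assay, bromo in place of fluoro on an aromatic carbon gives a number 0.64 log units higher from compound 2 to compound 4 (beyond the scatter), so the identity of the halogen at this position matters in this read-out. Going by these compounds alone, the earlier one-place step, a number 0.19 log units lower from compound 1 to compound 3 (within the scatter), involved a different exchange and lay within the scatter, so this is the first single change to go beyond it. No measurement shown here offers an explanation for the rise.

The compounds shown leave open how an amine, a methoxy group or a nitrile in this same place would compare with fluoro and bromo. They also leave open whether the exchange of fluoro for bromo would move the number similarly on a core carrying a second ring substituent, as compound 1 and compound 3 do.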